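Ring Swap on a Saturated Carbon Bound to an Alkyne

The compounds below may be only part of what the source reports. "The series", "measured", "known", "first", "only" and "open" are said of these compounds alone.

Measured compounds:
compound 1 `CCOC(=O)N(C)CC#CCN1CCCC1`: > 100 mg/kg
compound 2 `CCOC(=O)N(C)CC#CCn1ccnc1`: 97 mg/kg
compound 3 `CCOC(=O)N(C)C(C)C#CCN1CCCC1`: > 100 mg/kg

In a functional assay on the whole organism for antagonist activity, with Mus musculus as the target (on this read-out higher numbers stand for an effect only at larger amounts of compound and lower numbers for an effect already at smaller amounts), compound 1 reaches only a limit of the assay, > 100 mg/kg. Compound 3 likewise reaches only a limit, > 100 mg/kg. Compound 2 gives an actual number, 97 mg/kg. The change from compound 1 to compound 2 is 1H-imidazol-1-yl in place of pyrrolidin-1-yl on a saturated chain carbon bound to a triple-bonded carbon and produced a step of an at least 1.0-fold lower number from compound 1 to compound 2 (0.01 log units; that floor lies within the scatter); its true size is hard to judge because two of the three values sit at the limit of > 100 mg/kg in this assay, at which 2 of the 3 values shown sit. The change from compound 1 to compound 3 is methyl in place of hydrogen on a saturated chain carbon bound to an amide-type nitrogen and a triple-bonded carbon, a step that the two limits leave unreadable from compound 1 to compound 3.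

Compound 4 `CCOC(=O)N(C)C(C)C#CCn1ccnc1` has not been measured in this assay. It differs from compound 3 by 1H-imidazol-1-yl in place of pyrrolidin-1-yl on a saturated chain carbon bound to a triple-bonded carbon, the same change that separates compound 1 from compound 2. Since that change gave only an at least 1.0-fold lower number from compound 1 to compound 2 (0.01 log units; that floor lies within the scatter), the expected step of a number no higher from compound 3 to compound 4 (the limit leaves the size open) is estimated to be just as small. Compound 4 is therefore expected to come out near 100 mg/kg, likely between 50 mg/kg and 200 mg/kg, and quite possibly again only as a limit.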

Compound 4, dose for half-maximal effect: 66 mg/kg
Compound 4: middle estimate off by 1.5-fold (0.18 log units), on the high side; measured number inside the range.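

Carried onto the core of compound 3, the swap of pyrrolidin-1-yl for 1H-imidazol-1-yl in this assay gives an at least 1.5-fold lower number from compound 3 to compound 4 (0.18 log units; that floor lies within the scatter), and the two cores can be set side by side: the same change on two cores in this assay, an at least 1.0-fold lower number (0.01 log units; that floor lies within the scatter) from compound 1 to compound 2 and an at least 1.5-fold lower number (0.18 log units; that floor lies within the scatter) from compound 3 to compound 4; the limit leaves it open whether they differ
On both cores, the compound with 1H-imidazol-1-yl gives an actual number where its pyrrolidin-1-yl partner stays at a limit, but this does not show that the step is the same size on both cores, or that it exceeds the scatter on either: the limit of > 100 mg/kg in this assay, at which 2 of the 4 values shown sit.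
The added methyl, read on the pair that has two actual numbers, gives a 1.5-fold lower number from compound 2 to compound 4 (0.17 log units; within the scatter), so it shows no readable effect of its own.

The compounds shown leave open whether any group on a saturated chain carbon bound to a triple-bonded carbon can move the dose clearly beyond the scatter, for example a piperidin-1-yl ring or a dimethylamino group. They also leave open what an ethyl group would do in place of the added methyl.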